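A few compounds are considered here, and "the series" means these few. Any claim that something is new, unique, unknown or untested is made for them only; others in the source may bear on it.

Measured compounds:
compound 1 `CCOc1ccc2nc(C(=O)Nc3c(F)cc(-c4cccc(F)c4)cc3F)c(C)c(O)c2c1` — 0.68%
compound 2 `Cc1c(C(=O)Nc2c(F)cc(-c3cccc(F)c3)cc2F)nc2ccc(OC(F)(F)F)cc2c1O` — -0.35%
compound 3 `Cc1c(C(=O)Nc2c(F)cc(-c3cccc(F)c3)cc2F)nc2ccc(C(F)(F)F)cc2c1O` — 1.28%

In a functional assay on A-375 cells (Homo sapiens) for antiproliferative activity, read by MTT assay, with a stated time of 24 h, tested at 0.02 ug/mL (on this read-out lower numbers stand for a weaker effect and higher numbers for a stronger effect at the one concentration tested), compound 1 gives 0.68%, compound 2 gives -0.35% and compound 3 gives 1.28%. Compound 3 holds the highest of the three numbers, but its margin is slight: the step of a number 0.6 percentage points higher from compound 1 to compound 3 (within the scatter) and the step of a number 1.6 percentage points higher from compound 2 to compound 3 (within the scatter) both lie within the scatter, as does the step of a number 1 percentage points lower from compound 1 to compound 2 (within the scatter). The three compounds are thus indistinguishable in this assay at the concentration tested, and no order among them can be read.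

Compound 4 `Cc1c(C(=O)Nc2c(F)cc(-c3cccc(F)c3)cc2F)nc2ccc(C(F)(F)F)cc2c1C(=O)O` is unmeasured. It differs from compound 3 in one place: carboxy in place of hydroxy on an aromatic carbon. None of the three measured steps touches this position; each of them exchanges a group at a different aromatic carbon, and each stays within the scatter. Going by the values given here, there is therefore no measured step that speaks to what a carboxy in place of hydroxy does here, and the only guide is the flat picture across compounds 1, 2 and 3. On that basis a step of about a number 0.3 percentage points lower from compound 3 to compound 4 (within the scatter) is expected, meaning no movement beyond the scatter. Compound 4 is accordingly estimated at 1%, with a range from -8% to 10%.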

Compound 4, a percentage reported as inhibition, at one concentration (the size of the read-out at that concentration, not a potency): 0.37%
Estimate against measurement, compound 4: 0.6 percentage points above; measured number inside the range.
By their numbers in this assay, from the lowest: compounds 2, 4, 1 and 3 (each within the scatter of the next).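

Going by these compounds alone, the position opposite the ring nitrogen, untouched by the earlier steps, now has a measured step of its own: in this assay, carboxy in place of hydroxy gives a number 0.9 percentage points lower from compound 3 to compound 4 (within the scatter) and so adds to the three exchanges among ethoxy, trifluoromethoxy and trifluoromethyl elsewhere on the shared core, none of which left the scatter either. The entering carboxy brings three heavy atoms where hydroxy brought one, and this larger group on an aromatic carbon, ortho to a methyl group, gives no number that can be told apart from that of the hydroxy compound at the one concentration tested, so this change at this position shows no effect in this read-out, though that is a finding about this one pair and this one concentration only. Nothing at hand accounts for this step or bears on why the number stays where it does.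

What an amine, a methoxy group or a longer chain would do at this same aromatic carbon remains open, since hydroxy and carboxy are the only two groups shown there. From the compounds shown here alone, with all four compounds read at a single concentration, it also remains open whether the position matters at all under conditions where the read-out rises clear of the scatter.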